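Chain changes on an amide carbonyl, now with chlorine

This account rests on a few compounds, and the source may have more. Where it says the series, first, only, none or still open, it means among the compounds named here.

Compound 1, `CCC(=O)Nc1ccc(S(=O)(=O)Oc2ccccc2I)cc1`, gives 8100 nM in a functional assay on MCF7 cells (Homo sapiens) for antiproliferative activity, read by sulforhodamine B assay, with a stated time of 48 h; a lower number here means a stronger inhibitor, a higher number a weaker inhibitor.
Compound 2, `CCCC(=O)Nc1ccc(S(=O)(=O)Oc2ccccc2I)cc1`, gives 9700 nM in this assay.
Compound 3, `CC(C)C(=O)Nc1ccc(S(=O)(=O)Oc2ccccc2I)cc1`, gives 8100 nM in this assay.

All three share one core and differ only in the chain attached to the carbonyl carbon of the amide. Compound 3 stands level with compound 1 at the digits shown, and together they have the lowest of the three numbers, but the step of no change at the digits printed from compound 1 to compound 3 (within the scatter), the step of a 1.2-fold lower number from compound 2 to compound 3 (0.08 log units; within the scatter) and the step of a 1.2-fold higher number from compound 1 to compound 2 (0.08 log units; within the scatter) all lie within the usual scatter, so the three measured compounds are not separated from one another.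

Compound 4, `O=C(CCl)Nc1ccc(S(=O)(=O)Oc2ccccc2I)cc1`, differs from compound 3 by chloromethyl in place of isopropyl on a carbonyl carbon. The measured steps each changed only the length or branching of the chain on the carbonyl carbon, and none moved the number beyond the scatter. Within the data shown here, none of them brings in a chlorine, so no measured step speaks directly to this change; the only guide is that chain changes at this position have so far left this assay unmoved. The expected step is therefore a 1.2-fold lower number from compound 3 to compound 4 (0.06 log units; within the scatter), meaning no change beyond the scatter, with a wider range to allow for the unfamiliar group. Compound 4 is estimated at 7000 nM, between 2000 nM and 20000 nM.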

Compound 4, half-maximal inhibitory concentration: 2500 nM
Beside the measured number, compound 4's estimate is 2.8-fold (0.45 log units) above it; low and high end bracket the measured number.
By their numbers in this assay, from the lowest: compound 4; then compounds 1, 3 and 2 (each within the scatter of the next).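

This place on the carbonyl carbon, which looked indifferent while only the length or branching of the chain changed, does respond in this assay when a chlorine enters: chloromethyl in place of isopropyl gives a 3.2-fold lower number from compound 3 to compound 4 (0.51 log units; beyond the scatter) and is a modest but real move. The other two comparisons agree, with a 3.2-fold lower number from compound 1 to compound 4 (0.51 log units; beyond the scatter) and a 3.9-fold lower number from compound 2 to compound 4 (0.59 log units; beyond the scatter) both also lying beyond the scatter. Compound 1, compound 2 and compound 3 remain unseparated from one another, while compound 4 stands apart from all of them as the strongest inhibitor of the four, so the chain on the amide carbonyl is not a part of the molecule that can be changed freely without any effect.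

In this single change the chlorine arrives and the carbon chain gets shorter at the same time, so a chlorine-free methyl group, together with bromomethyl, methoxymethyl or aminomethyl, would be needed to tell whether the chlorine itself or some other feature of the new group goes with the lower number. Nothing among the data shown gives a reason for this step, and the numbers record only that it happened.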